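The source may hold more compounds than are shown below. What is called first, only, known or untested is meant among the compounds shown, and "the series" means these compounds.

Of the compounds shown here, three sharing one core have been tested so far: compound 1 `CN(C)CCn1cnnc1-c1cc(Oc2ccc(NC(=O)Nc3ccc(Cl)c(C(F)(F)F)c3)cc2F)ccn1`, compound 2 `CN(C)CCn1cnnc1-c1cc(Oc2ccc(NC(=O)Nc3cccc(C(F)(F)F)c3)cc2F)ccn1` and compound 3 `CN(C)CCn1cnnc1-c1cc(Oc2ccc(NC(=O)Nc3ccccc3C(F)(F)F)cc2F)ccn1`. They differ only in the aryl group carried by the urea nitrogen. In a functional assay on HT-29 cells (Homo sapiens) for antiproliferative activity, read by MTT assay, with a stated time of 72 h (a lower number here means a stronger inhibitor, a higher number a weaker inhibitor), compound 1 gives 880 nM, compound 2 gives 1470 nM and compound 3 gives 5860 nM. Compound 3 thus stands highest of the three; the shift a 6.7-fold higher number from compound 1 to compound 3 (0.82 log units; beyond the scatter) and the shift a 4.0-fold higher number from compound 2 to compound 3 (0.60 log units; beyond the scatter) both lie beyond the scatter, while a 1.7-fold higher number from compound 1 to compound 2 (0.22 log units; within the scatter) does not.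

Compound 4 `CN(C)CCn1cnnc1-c1cc(Oc2ccc(NC(=O)Nc3ccc(F)c(F)c3)cc2F)ccn1` has not yet been measured. Compared with compound 3 the change is 3,4-difluorophenyl in place of 2-(trifluoromethyl)phenyl on an amide-type nitrogen. The two steps that bear on it, a 6.7-fold higher number from compound 1 to compound 3 (0.82 log units; beyond the scatter) and a 4.0-fold higher number from compound 2 to compound 3 (0.60 log units; beyond the scatter), both show that replacing a 2-(trifluoromethyl)phenyl group by an aryl group substituted only at the 3 and 4 positions gave lower numbers; compound 4 goes in that same direction, so a lower number than compound 3 is expected in this assay, though a 3,4-difluorophenyl group itself has not been tested here. The step expected is a 4.5-fold lower number from compound 3 to compound 4 (0.65 log units; beyond the scatter), giving an estimate for compound 4 of 1300 nM with a range from 500 nM to 3500 nM.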

Compound 4, half-maximal inhibitory concentration: 3620 nM
Beside the measured number, compound 4's estimate is 2.8-fold (0.44 log units) below it; measured number above the stated range.
By their numbers in this assay, from the lowest: compounds 1 and 2 (each within the scatter of the next); then compounds 4 and 3 (each within the scatter of the next).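

In this assay, among these compounds, the earlier compounds left open whether any aryl group in place of 2-(trifluoromethyl)phenyl on the amide-type nitrogen would give a lower number, but 3,4-difluorophenyl cannot be told apart from it (a 1.6-fold lower number from compound 3 to compound 4 (0.21 log units; within the scatter)). The 3,4-difluorophenyl group also gives higher numbers than 3-(trifluoromethyl)phenyl (a 2.5-fold higher number from compound 2 to compound 4 (0.39 log units; beyond the scatter)) and 4-chloro-3-(trifluoromethyl)phenyl (a 4.1-fold higher number from compound 1 to compound 4 (0.61 log units; beyond the scatter)), so the lower numbers of those two groups do not follow simply from the absence of 2-(trifluoromethyl)phenyl. Nothing available here explains these differences.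

Every aryl group shown carries fluorine, so plain phenyl and 4-methoxyphenyl remain open at this position. Single-fluorine groups such as 3-fluorophenyl and 4-fluorophenyl also remain open, and they would show how each fluorine of 3,4-difluorophenyl contributes.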